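The source may report more compounds than this note shows. Statements on the series, on what has been measured and on what is new or still open speak of the compounds shown alone.

In a functional assay on K562 cells (Homo sapiens) for cytotoxicity, read by trypan blue exclusion, with a stated time of 96 h (a higher number here means a weaker inhibitor, a lower number a stronger inhibitor), compound 1 (`COc1ccc(/C=C/S(=O)(=O)Cc2ccc(OC)c(N)c2)cc1`) gives 2500 nM, and compound 2 (`COc1cc(OC)c(/C=C/S(=O)(=O)Cc2ccc(OC)c([N+](=O)[O-])c2)c(OC)c1`) gives 2500 nM. Compound 3 (`COC(=O)C(F)(F)Nc1cc(CS(=O)(=O)/C=C/c2c(OC)cc(OC)cc2OC)ccc1OC`) gives 250 nM, the lowest number of the three.

Compound 4 (`COC(=O)C(Nc1cc(CS(=O)(=O)/C=C/c2c(OC)cc(OC)cc2OC)ccc1OC)c1ccc(Br)cc1`) departs from compound 3 on a nitrogen on an aromatic ring, where (4-bromophenyl)(methoxycarbonyl)methyl stands in place of difluoro(methoxycarbonyl)methyl: (4-bromophenyl)(methoxycarbonyl)methyl in place of difluoro(methoxycarbonyl)methyl on a nitrogen on an aromatic ring.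

Among the compounds with values here, only one measured step bears on this place. It is a 10-fold lower number from compound 2 to compound 3 (1.00 log units; beyond the scatter), with (difluoro(methoxycarbonyl)methyl)amino in place of nitro on an aromatic carbon. That step shows that the number can move beyond the scatter when this substituent changes, but it says nothing direct about the group that now enters. Within the data shown here, no measured compound carries (4-bromophenyl)(methoxycarbonyl)methyl, so the data give no direction for this exchange. The methoxycarbonyl part stays in both groups, so the expectation starts from compound 3 at 250 nM and leans slightly upward, with wide margins.

The estimate for this change is a 1.2-fold higher number from compound 3 to compound 4 (0.08 log units; within the scatter), and no shift beyond the scatter is expected. Compound 4 is expected at about 300 nM, with an estimated range from 80 nM to 1200 nM.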

Compound 4, half-maximal inhibitory concentration: 200 nM
The estimate for compound 4 lay 1.5-fold (0.18 log units) above the measured number; low and high end bracket the measured number.
By their numbers in this assay, from the lowest: compounds 4 and 3 (each within the scatter of the next); then compounds 1 and 2 (each within the scatter of the next).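

At the nitrogen on an aromatic ring, exchanging difluoro(methoxycarbonyl)methyl for (4-bromophenyl)(methoxycarbonyl)methyl gives, in this assay, a 1.3-fold lower number from compound 3 to compound 4 (0.10 log units; within the scatter), so a group with 12 heavy atoms, including a six-membered aromatic ring of carbon only and a bromine, replaces one with 7 heavy atoms and no ring, without a shift beyond the scatter. Within the data shown here, the only earlier step at this place, a 10-fold lower number from compound 2 to compound 3 (1.00 log units; beyond the scatter), showed that the number can respond to a change of substituent, whereas this step shows that two quite different groups, both carrying methoxycarbonyl, cannot be told apart in this assay. Nothing measured here offers an explanation for how closely the two numbers agree.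

The compounds shown leave open whether the bromine contributes anything, as no compound here carries a plain phenyl ring or a chlorine in its place. They also leave open whether the methoxycarbonyl part is needed, which a carboxylic acid or an amide at that point of the group would address.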